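Benzyl in Place of Hydrogen: Compound 4 Awaits Testing

The source may report more compounds than this note shows. Statements on the series, on what has been measured and on what is new or still open speak of the compounds shown alone.

Of the compounds shown here, three sharing a common core have been tested in a functional assay on A-431 cells (Homo sapiens) for cytotoxicity, read by resazurin assay, with a stated time of 72 h; on this read-out higher numbers stand for weaker inhibition and lower numbers for stronger inhibition. Compound 1 `Clc1nss/c1=N\c1cccc(Br)c1` reached only the limit of the assay, recorded as > 100000 nM. Compound 2 `Cc1cc(/N=c2\ssnc2Cl)n[nH]1` gave a numerical reading in this assay of 69000 nM. Compound 3 `Clc1nss/c1=N\c1cc(-c2ccccc2)n[nH]1`, the starting point of this account, likewise sits at a limit rather than a number, reported as > 100000 nM. Two of the three values therefore fall at the limit of > 100000 nM in this assay, at which 2 of the 3 values shown sit, and nothing in the set places compound 3 relative to the others beyond that.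

Compound 4 `Clc1nss/c1=N\c1cc(-c2ccccc2)nn1Cc1ccccc1` differs from compound 3 by a single change: benzyl in place of hydrogen on an aromatic nitrogen. Within the data shown here, no measured pair in the set shows this change, so its size cannot be read from the data. With compound 3 reported only as a limit, compound 4 is expected to remain close to it, with a step of a number no higher from compound 3 to compound 4 (the limit leaves the size open) in this assay of no size beyond the scatter. Compound 4 is accordingly estimated at 100000 nM, within a range from 30000 nM to 300000 nM, and most likely again recorded only as a limit.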

Compound 4, half-maximal inhibitory concentration: > 100000 nM
Compound 4: a limit, no number; the forecaster's own chance of this, stated with the estimate: 70%; the middle value sits exactly at the limit.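

In this assay, among these compounds, compound 3 and compound 4 are both recorded only as limits, so no step between them can be read: the limit of > 100000 nM in this assay, at which 3 of the 4 values shown sit. The compounds shown leave open whether benzyl in place of hydrogen on an aromatic nitrogen changes this read-out at all.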